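A side arm returns to the amine nitrogen

A few compounds are considered here, and "the series" means these few. Any claim that something is new, unique, unknown or untested is made for them only; others in the source may bear on it.

The three measured compounds share a core built from two diphenylpropyl arms joined through amide and amine links. In an ADME assay on Jurkat cells (Homo sapiens) for cytotoxicity, with a stated time of 72 h (a higher number here means a weaker inhibitor of growth, a lower number a stronger inhibitor of growth), compound 1 `NC(=O)CN(CCC(c1ccccc1)c1ccccc1)C(=O)CN(CCC(c1ccccc1)c1ccccc1)C(=O)CNCC1CCCO1` gives 21300 nM. Compound 2 `NC(=O)CN(CCC(c1ccccc1)c1ccccc1)C(=O)CNCCC(c1ccccc1)c1ccccc1` gives 10500 nM in this assay, and compound 3 `O=C(CNCCC(c1ccccc1)c1ccccc1)NCCC(c1ccccc1)c1ccccc1` gives 10200 nM. Two steps connect them: a 2.0-fold lower number from compound 1 to compound 2 (0.31 log units; beyond the scatter), and a 1.0-fold lower number from compound 2 to compound 3 (0.01 log units; within the scatter). Compound 3 therefore stands at the lowest of the three numbers, but its gap to compound 2 lies within the scatter; only compound 1 sits beyond the scatter above it, so compound 3 cannot be called the strongest inhibitor of growth on these data.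

Compound 4 `O=C(CN(CCC(c1ccccc1)c1ccccc1)C(=O)CNCC1CCCO1)NCCC(c1ccccc1)c1ccccc1` arises from compound 3 by ((((oxolan-2-yl)methyl)amino)methyl)carbonyl in place of hydrogen on an amine nitrogen. Going by the values given here, the single measured step that bears on this change is a 2.0-fold lower number from compound 1 to compound 2 (0.31 log units; beyond the scatter), in which the same group left the same kind of amine nitrogen and the number fell modestly. The move from compound 3 to compound 4 reverses that change, so the number is expected to rise by a comparable, modest amount: a 2.0-fold higher number from compound 3 to compound 4 (0.29 log units; within the scatter) is the expected step. Compound 4 is accordingly estimated at 20000 nM in this assay, with a plausible range from 10000 nM to 40000 nM.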

Compound 4, concentration for 50% growth inhibition: 5830 nM
Estimate against measurement, compound 4: 3.4-fold (0.54 log units) above, outside the stated range (below it).
By their numbers in this assay, from the lowest: compounds 4, 3 and 2 (each within the scatter of the next); then compound 1.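

In this assay the entry of ((((oxolan-2-yl)methyl)amino)methyl)carbonyl on the amine nitrogen gives a 1.7-fold lower number from compound 3 to compound 4 (0.24 log units; within the scatter) and so brings no measurable rise on this core. The same exchange therefore does not carry over from one core to the other: the same change on two cores in this assay, a 2.0-fold lower number (0.31 log units; beyond the scatter) from compound 1 to compound 2 and a 1.7-fold higher number (0.24 log units; within the scatter) from compound 4 to compound 3, 3.5-fold (0.55 log units) apart, beyond the scatter of two such steps. The carbamoylmethyl group on the amide-type nitrogen also behaves differently on the two cores, since hydrogen in its place gives a 3.7-fold lower number from compound 1 to compound 4 (0.56 log units; beyond the scatter) on the core that carries the side arm, whereas it made no difference beyond the scatter on the core without it: the same change on two cores in this assay, a 1.0-fold lower number (0.01 log units; within the scatter) from compound 2 to compound 3 and a 3.7-fold lower number (0.56 log units; beyond the scatter) from compound 1 to compound 4, 3.5-fold (0.55 log units) apart, beyond the scatter of two such steps.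

The compounds shown leave open whether this dependence on the core extends to other groups on the amine nitrogen, such as a plain acetyl or an aminoacetyl without the oxolane ring. Going by these compounds alone, they also leave open whether a carboxylic acid in place of the terminal amide of the carbamoylmethyl group would follow the same course, and each change here rests on only two pairs of compounds.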